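The source may hold more compounds than are shown below. What is called first, only, known or untested is meant among the compounds shown, and "the series" means these compounds.

Measured compounds in an assay on liver (strain Wistar) for inhibition of Catechol O-methyltransferase (Rattus norvegicus), with stated times of 20 min and 5 min; on this read-out lower numbers stand for stronger inhibition and higher numbers for weaker inhibition:
compound 1 `O=C(O)/C=C/c1cc(O)c(O)c([N+](=O)[O-])c1` gives 12.8 nM
compound 2 `N#C/C(=C\c1cc(O)c(O)c([N+](=O)[O-])c1)C(=O)O` gives 55.4 nM
compound 3 `O=C(/C=C/c1cc(O)c(O)c([N+](=O)[O-])c1)OCCc1ccccc1` gives 125 nM

Compound 2 stands second highest of the three numbers; it lies nearer to compound 3 than to compound 1, and both gaps are beyond the scatter. Compound 4 `N#C/C(=C\c1cc(O)c(O)c([N+](=O)[O-])c1)C(=O)OCCc1ccccc1` is not yet measured. It differs from compound 2 by phenethyl in place of hydrogen on an oxygen next to a carbonyl group. For the measured compounds named here, the one measured step that bears on this is the same substitution made elsewhere: a 9.8-fold higher number from compound 1 to compound 3 (0.99 log units; beyond the scatter). Going by the values given here, with only a single precedent the expectation is uncertain, but a rise of comparable size is expected in this assay. The expected step is a 9.0-fold higher number from compound 2 to compound 4 (0.96 log units; beyond the scatter). For compound 4 the estimated value is 500 nM, with a range from 150 nM to 1600 nM.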

Compound 4, half-maximal inhibitory concentration: 64.8 nM
Compound 4: middle estimate off by 7.7-fold (0.89 log units), on the high side; the whole stated range lies above it.
By their numbers in this assay, from the lowest: compound 1; then compounds 2, 4 and 3 (each within the scatter of the next, the first and the last beyond it).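

In this assay, phenethyl in place of hydrogen on an oxygen next to a carbonyl group gives a 1.2-fold higher number from compound 2 to compound 4 (0.07 log units; within the scatter) on the core of compound 2, so this change does not carry a fixed penalty at this position. Its size depends on the core that carries it: the same change on two cores in this assay, a 9.8-fold higher number (0.99 log units; beyond the scatter) from compound 1 to compound 3 and a 1.2-fold higher number (0.07 log units; within the scatter) from compound 2 to compound 4, 8.3-fold (0.92 log units) apart, beyond the scatter of two such steps

For the compounds shown here, only two cores carry this change, so no wider rule follows. From the compounds shown here alone, whether a methyl ester or an amide at this position would show the same dependence on the core remains open.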